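Side-chain change from compound 2 to compound 3

A few compounds are considered here, and "the series" means these few. Any claim that something is new, unique, unknown or untested is made for them only; others in the source may bear on it.

- compound 1 `C=CC(=O)Nc1cccc(Nc2nc(Nc3ccc(OCC(=O)N(CCOC)CCOC)cc3)ncc2Cl)c1` gives 18100 nM
- compound 2 `C=CC(=O)Nc1cccc(Nc2nc(Nc3ccc(OCC4CCCO4)cc3)ncc2Cl)c1` gives 10500 nM

In a functional assay on Ramos cells (Homo sapiens) for antiproliferative activity, read by CCK-8 assay, with a stated time of 48 h (a lower number here means a stronger inhibitor, a higher number a weaker inhibitor), compound 2 stands at 10500 nM and compound 1 stands at 18100 nM, and the two values are not separated. Going by the values given here, the one measured step, a 1.7-fold lower number from compound 1 to compound 2 (0.24 log units; within the scatter), stays within the scatter.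

Compound 3 `C=CC(=O)Nc1cccc(Nc2nc(Nc3ccc(OCC(=O)OCC4CCCO4)cc3)ncc2Cl)c1` has not been measured. Its difference from compound 2 is ((oxolan-2-yl)methoxy)carbonyl in place of oxolan-2-yl on a saturated chain carbon bound to an oxygen on an aromatic ring. In words, this is ((oxolan-2-yl)methoxy)carbonyl in place of oxolan-2-yl on a saturated chain carbon bound to an oxygen on an aromatic ring. Compound 3 thus keeps the oxolan-2-yl ring of compound 2 and, like compound 1, has a carbonyl on that chain carbon.

Among the compounds with values here, the step from compound 1 to compound 2 is the only evidence at this place, and it is a single step, so the expectation is loose. With a 1.7-fold lower number from compound 1 to compound 2 (0.24 log units; within the scatter) as the guide, no change beyond the scatter is expected in this assay. The estimated step is a 1.0-fold higher number from compound 2 to compound 3 (0.02 log units; within the scatter). The expected value for compound 3 is 11000 nM, with an estimated range of 5000 nM to 25000 nM.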

Compound 3, half-maximal inhibitory concentration: > 40000 nM
Compound 3: only a limit was reported (the forecaster's own chance of this, stated with the estimate: 10%); at least 3.6-fold (0.56 log units) between middle value and limit.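

In this assay compound 3 gives only a limit, > 40000 nM, and this is a limit of the assay, not a number. Putting ((oxolan-2-yl)methoxy)carbonyl in place of oxolan-2-yl on a saturated chain carbon bound to an oxygen on an aromatic ring gives an at least 3.8-fold higher number from compound 2 to compound 3 (0.58 log units; beyond the scatter), so this place does respond to a change of side chain, which the earlier step, within the scatter, did not show. Putting (oxolan-2-yl)methoxy in place of bis(2-methoxyethyl)amino on a carbonyl carbon gives an at least 2.2-fold higher number from compound 1 to compound 3 (0.34 log units; beyond the scatter), so among the compounds shown the weaker result appears only where the oxolan-2-yl ring and the carbonyl occur together.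

On these data alone, whether a carboxylic acid or a piperidine amide on that carbonyl carbon would keep the level of the other two compounds remains open. The true size of both new steps also remains open, and they give no cause for the weakening, since they rest on a single limit: the limit of > 40000 nM in this assay, at which 1 of the 3 values shown sits.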